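Aryl group change from compound 2 to compound 3

A few compounds are considered here, and "the series" means these few. Any claim that something is new, unique, unknown or untested is made for them only; others in the source may bear on it.

Measured in a functional assay on OVCAR-5 cells (Homo sapiens) for inhibition, read by CCK-8 assay, with a stated time of 72 h, tested at 10 uM; on this read-out lower numbers stand for less inhibition of growth and higher numbers for more inhibition of growth at the one concentration tested:
compound 1 `CN(C)C(=O)c1cc2cnc(Nc3ccc(NC(=O)C4(C(=O)Nc5cccc(O)c5)CC4)cc3)nc2n1C1CCCC1`: 86%
compound 2 `CN(C)C(=O)c1cc2cnc(Nc3ccc(NC(=O)C4(C(=O)Nc5ccccc5F)CC4)cc3)nc2n1C1CCCC1`: 82.6%

Compound 2, at 82.6%, lies within the scatter of compound 1, so the two values cannot be ranked. Compound 3 `CN(C)C(=O)c1cc2cnc(Nc3ccc(NC(=O)C4(C(=O)Nc5cccc(Cl)c5)CC4)cc3)nc2n1C1CCCC1` carries 3-chlorophenyl in place of 2-fluorophenyl on an amide-type nitrogen. Among the compounds with values here, the only measured step at this place is a number 3.4 percentage points lower from compound 1 to compound 2 (within the scatter), for 2-fluorophenyl in place of 3-hydroxyphenyl. Within the data shown here, no compound with a 3-chlorophenyl group has been measured, so this single step is a thin guide. On that evidence, no step beyond the scatter is expected in this assay. The expected change is a number 0.4 percentage points higher from compound 2 to compound 3 (within the scatter). Compound 3 is estimated at 83%, with an expected range of 71% to 93%.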

Compound 3, percent growth inhibition at one concentration: 88.1%
Estimate against measurement, compound 3: 5.1 percentage points below, and the stated range covers the measured number.
By their numbers in this assay, from the lowest: compounds 2, 1 and 3 (each within the scatter of the next).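

In this assay the change to 3-chlorophenyl on the amide-type nitrogen gives a number 5.5 percentage points higher from compound 2 to compound 3 (within the scatter) and chloro in place of hydroxy on an aromatic carbon gives a number 2.1 percentage points higher from compound 1 to compound 3 (within the scatter) so this position now holds three differently substituted phenyl groups that the single concentration does not separate. Compound 3 carries no hydroxy group and still lies within the scatter of compound 1, so the hydroxy group of compound 1 is not required for this read-out among the compounds shown. Nothing at hand explains these numbers.

Going by these compounds, whether an aminophenyl group, a carboxylic acid on the ring or a longer chain in place of the phenyl group would stay within this range remains open. Also open, on these data alone, is whether these three compounds would separate at lower concentrations.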